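A few compounds are considered here, and "the series" means these few. Any claim that something is new, unique, unknown or untested is made for them only; others in the source may bear on it.

Of the compounds shown here, two from this series have been tested in a functional assay on M14 cells (Homo sapiens) for inhibition, read by sulforhodamine B assay, with a stated time of 48 h; on this read-out higher numbers stand for weaker inhibition of growth and lower numbers for stronger inhibition of growth. Compound 1, `O=C(Nc1cccc(-n2cc(-c3ccncc3)c(-c3ccc(Cl)c(O)c3)n2)c1)Nc1cccc(C(F)(F)F)c1`, gives 10800 nM in this assay. Compound 2, `COc1cc(-c2nn(-c3cccc(NC(=O)Nc4ccc(Cl)c(C(F)(F)F)c4)c3)cc2-c2ccncc2)ccc1Cl`, gives 3710 nM in this assay, the lowest of the two numbers; the gap to compound 1 is beyond the usual scatter. Compound 1 and compound 2 differ in more than one place, so their two values alone show the difference between them.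

Compound 3, `O=C(Nc1cccc(-n2cc(-c3ccncc3)c(-c3ccc(Cl)c(O)c3)n2)c1)Nc1ccc(Cl)c(C(F)(F)F)c1`, has not yet been measured in this assay. It differs from compound 2 by a single change: hydrogen in place of methyl on an oxygen on an aromatic ring. Among the compounds with values here, compound 1 also carries the hydroxy group, but it differs from compound 3 elsewhere as well, so no measured pair isolates this single change.

Within the data shown here, with no direct precedent, the expected step from compound 2 to compound 3 in this assay is a 1.6-fold higher number from compound 2 to compound 3 (0.21 log units; within the scatter), a modest move toward weaker growth inhibition, possibly within the scatter. For compound 3 the estimated total growth inhibition concentration is 6000 nM, with a range from 2000 nM to 18000 nM.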

Compound 3, concentration for total growth inhibition: 2770 nM
Compound 3: the middle estimate sits 2.2-fold (0.34 log units) above what was measured, within the range that was stated.
By their numbers in this assay, from the lowest: compounds 3 and 2 (each within the scatter of the next); then compound 1.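

Within the data shown here, with compound 3, the change from methoxy to hydroxy on the 4-chloro-3-methoxyphenyl group can be read on its own for the first time: in this assay, the step is a 1.3-fold lower number from compound 2 to compound 3 (0.13 log units; within the scatter), so the two groups cannot be told apart at this position on this read-out. Compound 3 also isolates a second change, chloro in place of hydrogen on an aromatic carbon, with a 3.9-fold lower number from compound 1 to compound 3 (0.59 log units; beyond the scatter); this clears the scatter and shows that, with the hydroxy group held constant, this single site separates two compounds where the hydroxy-to-methoxy change does not. No measurement is available to explain either result.

The compounds shown leave open whether the chloro step would carry over to compounds bearing methoxy rather than hydroxy, and whether bromo or fluoro on the same aromatic carbon would give a similar step. They also leave open whether a longer chain such as propyl on the oxygen, or an amine in place of the hydroxy group, would stay level with compound 2 and compound 3.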